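Amide aryl swap on the methoxyphenyl imidazole core

The compounds below may be only part of what the source reports. "The series", "measured", "known", "first", "only" and "open" are said of these compounds alone.

Measured so far:
- compound 1, `COc1ccc(-c2nc3ncc(-c4ccc(F)cc4)cc3[nH]2)cc1`: > 100000 nM
- compound 2, `COc1ccc(-c2cnc(NC(=O)c3ccco3)n2C)cc1`: > 100000 nM

Both values come from a toxicity assay on THP-1 cells (Homo sapiens) for inhibition; on this read-out higher numbers stand for lower toxicity in this test and lower numbers for higher toxicity in this test. For compound 1 the value > 100000 nM is a limit of the assay, not a number. For compound 2 the value > 100000 nM is likewise a limit of the assay and not a number. Going by the values given here, compound 2 therefore stands at the limit of > 100000 nM in this assay, at which 2 of the 2 values shown sit; nothing in the two results separates it from compound 1, and no step between measured compounds can be computed here.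

Compound 3, `COc1ccc(-c2cnc(NC(=O)c3ccccc3Br)n2C)cc1`, keeps the core of compound 2 and changes only the amide aryl group: 2-bromophenyl in place of furan-2-yl on a carbonyl carbon. Among the compounds with values here, since both measured values sit at the limit, there is no measured step from which the size or direction of this change could be read, and no effect beyond the usual scatter is expected in this assay. Compound 3 is accordingly expected to remain near the limit, with the expected step of a number no higher from compound 2 to compound 3 (the limit leaves the size open) amounting to no change beyond the scatter. The estimate for compound 3 is 100000 nM, within 30000 nM to 300000 nM.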

Compound 3, half-maximal cytotoxic concentration: > 100000 nM
Compound 3: only a limit was reported; the forecaster's own chance of this, stated with the estimate: 70%; the middle value sits exactly at the limit.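

In this assay compound 3 gives > 100000 nM as a limit of the assay, not a number. Going by these compounds alone, compound 2 and compound 3 both stand at a limit, so no step between them can be read: the limit of > 100000 nM in this assay, at which 3 of the 3 values shown sit. The compounds shown leave open whether the amide aryl group has any bearing on toxicity in this test.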